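This account rests on a few compounds, and the source may have more. Where it says the series, first, only, none or still open, it means among the compounds named here.

Measured so far:
- Compound 1, `O=C(Nc1cccc(S(=O)(=O)C2CCCC2)c1)c1cccnc1N1CCC(F)(F)CC1`: 4780 nM
- Compound 2, `CC(C)(C)NS(=O)(=O)c1cccc(NC(=O)c2cccnc2N2CCC3(CC2)CC3)c1`: 840 nM

Compound 2 stands lowest of the two numbers; the nearest is compound 1, whose number in a functional assay on OVCAR-3 cells (Homo sapiens) for antiproliferative activity (on this read-out higher numbers stand for an effect only at larger amounts of compound and lower numbers for an effect already at smaller amounts), is higher by a gap that lies beyond the usual scatter. The two compounds differ in more than one place, so the two values alone cannot tell which part of the structure carries that gap.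

Compound 3, `O=C(Nc1cccc(S(=O)(=O)C2CCCC2)c1)c1cccnc1N1CCC2(CC1)CC2`, is not yet measured. Compared with compound 2 it differs in one place: cyclopentyl in place of (tert-butyl)amino on a sulfonyl sulfur. The cyclopentylsulfonyl group is the same one found in compound 1, while the rest of the structure is that of compound 2.

For compound 3 a modest rise in this assay is expected, the step of a 1.9-fold higher number from compound 2 to compound 3 (0.28 log units; within the scatter), because compound 1, which carries the same cyclopentylsulfonyl group, gives 4780 nM. The estimate for compound 3 is therefore 1600 nM, within a range of 500 nM to 5000 nM.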

Compound 3, half-maximal effective concentration: 1240 nM
Beside the measured number, compound 3's estimate is 1.3-fold (0.11 log units) above it; the measured number falls inside the stated range.
By their numbers in this assay, from the lowest: compounds 2 and 3 (each within the scatter of the next); then compound 1.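

In this assay, putting cyclopentyl in place of (tert-butyl)amino on a sulfonyl sulfur gives a 1.5-fold higher number from compound 2 to compound 3 (0.17 log units; within the scatter) and so makes no clear difference, even though the hydrogen-bond donor leaves with the (tert-butyl)amino group. With cyclopentylsulfonyl held the same, the other place does show a clear step: a 3.9-fold lower number from compound 1 to compound 3 (0.59 log units; beyond the scatter) comes with the group holding a three-membered carbon ring in place of the fluorine-bearing group on an aromatic carbon. No measurement shown here explains either step.

As far as these compounds go, it remains open whether the sulfonyl sulfur tolerates quite different groups, such as a methyl or a morpholine, as it does these two. Also open, from the compounds shown here alone, is whether the (tert-butyl)sulfamoyl and cyclopentylsulfonyl groups would still match when paired with the fluorine-bearing group of compound 1.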